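The compounds below may be only part of what the source reports. "The series", "measured", "known", "first", "only" and "open" are said of these compounds alone.

Measured compounds:
- compound 1, `CCn1c(C(C)NS(=O)(=O)c2ccc(Cl)cc2)nc2cccnc21`, in an ADME assay (liver) for metabolic stability, with Liver microsome (Homo sapiens) as the target, read by LC-MS, using microsomes and NADPH, with a stated time of 5 min, at 37 degrees C (a lower number here means slower removal, a higher number faster removal of the compound), gives 94 mL.min-1.g-1.
- compound 2, `CCn1c([C@@H](C)NS(=O)(=O)c2cccc(Cl)c2)nc2ccc(C(F)(F)F)cc21`, in this assay gives > 100 mL.min-1.g-1.

Compound 2 stands at the limit of > 100 mL.min-1.g-1 in this assay, at which 1 of the 2 values shown sits, so for compound 2 only a limit is known, not a number: its clearance in this assay is reported as > 100 mL.min-1.g-1. Compound 1 gives a number, 94 mL.min-1.g-1, and both compounds therefore sit at the fast end of the scale of this assay, where the compound is removed quickly.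

Compound 3, `CCn1c([C@@H](C)NS(=O)(=O)c2cn(C)c(C)n2)nc2ccc(C(F)(F)F)cc21`, has not yet been measured in this assay. It differs from compound 2 in one place: 1,2-dimethyl-1H-imidazol-4-yl in place of 3-chlorophenyl on a sulfonyl sulfur.

Since no step between two measured compounds is shown, the size of the step from compound 2 to compound 3 is a guess. A decrease in clearance, beyond the usual scatter, is expected from this change, as an at least 2.5-fold lower number from compound 2 to compound 3 (0.39 log units; beyond the scatter). For compound 3 the expected result in this assay is 40 mL.min-1.g-1, with a range from 12 mL.min-1.g-1 to 100 mL.min-1.g-1.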

Compound 3, intrinsic clearance in microsomes: 43 mL.min-1.g-1
Compound 3: middle estimate off by 1.1-fold (0.03 log units), on the low side, within the range that was stated.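

In this assay compound 2 gives > 100 mL.min-1.g-1, which is a limit of the assay and not a number. Compounds 1 and 2 differ in more than one place, so they could not show the effect of any single change, whereas exchanging the group on a sulfonyl sulfur gives an at least 2.3-fold lower number from compound 2 to compound 3 (0.36 log units; beyond the scatter), and compound 3 gives 43 mL.min-1.g-1, a value that can be read as a number. This shows that removal in this assay responds to the group at this position, although the step is only a minimum and its full size remains unknown because compound 2 sits at a limit: the limit of > 100 mL.min-1.g-1 in this assay, at which 1 of the 3 values shown sits.

This single swap changes the ring size, brings in ring nitrogens and adds two methyl groups all at once, so the compounds shown cannot say which of these parts accounts for the step. As far as these compounds go, it also remains open how a plain phenyl, a pyridine ring or an imidazole without its methyl groups would behave at this position on the same core.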